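Swapping a Diazine Ring at the Limit of Cytotoxicity

The compounds below may be only part of what the source reports. "The series", "measured", "known", "first", "only" and "open" are said of these compounds alone.

In an ADME assay on L6 cells (Rattus norvegicus) for cytotoxicity, read by resazurin assay, with a stated time of 72 h (a higher number here means a weaker inhibitor, a lower number a stronger inhibitor), compound 1 `OC(c1ccc(Cl)cc1)(c1cccnc1)c1ccccc1Cl` gives 61300 nM. Compound 2 `OC(c1ccc(Cl)cc1)(c1cnccn1)c1ccccc1Cl` gives > 100000 nM, which is a limit of the assay and not a number. Its standing is therefore known only as the limit of > 100000 nM in this assay, at which 1 of the 2 values shown sits, and no exact place can be given to it. Compound 3 `OC(c1ccc(Cl)cc1)(c1ncccn1)c1ccccc1Cl` has the same atoms as compound 2, joined differently: pyrimidin-2-yl in place of pyrazin-2-yl on a saturated chain carbon bound to two aromatic carbons and an oxygen on a saturated carbon, with pyrimidin-2-yl in place of pyrazin-2-yl on a saturated chain carbon bound to two aromatic carbons and an oxygen on a saturated carbon. For the measured compounds named here, the only measured step that bears on this exchange is an at least 1.6-fold higher number from compound 1 to compound 2 (0.21 log units; that floor lies within the scatter). That step also exchanges the aromatic ring at this place, and its floor offers no ground for expecting a large move. The expected step is a number no higher from compound 2 to compound 3 (the limit leaves the size open), so no change beyond the scatter is anticipated in this assay. For compound 3 the estimated value is 100000 nM, within an expected range of 50000 nM to 200000 nM.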

Compound 3, half-maximal inhibitory concentration: > 100000 nM
Compound 3: a limit, no number; the forecaster's own chance of this, stated with the estimate: 55%; the middle value lies on the limit itself.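

In this assay compound 3 gives > 100000 nM, which is a limit of the assay and not a number, so pyrimidin-2-yl at this place ends at the same limit as pyrazin-2-yl. Set against pyridin-3-yl, the exchange gives an at least 1.6-fold higher number from compound 1 to compound 3 (0.21 log units; that floor lies within the scatter), so the second ring with two nitrogens adds only a floor that does not clear the scatter, and no real move away from compound 1 is shown. The step between compound 2 and compound 3 cannot be read, and the two ring arrangements cannot be ordered in this assay, where readings at this position now rest mostly on a ceiling: the limit of > 100000 nM in this assay, at which 2 of the 3 values shown sit.

Going by these compounds, how far compound 2 and compound 3 really lie past that limit stays open. So does whether a primary amine or a carboxylic acid on a ring at this place would bring the number into the readable range.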